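The source may report more compounds than this note shows. Statements on the series, on what has been measured and on what is new or still open speak of the compounds shown alone.

Measured compounds in an assay on thoracic aorta for inhibition of Voltage-gated L-type calcium channel (Rattus norvegicus); a higher number here means a weaker inhibitor, a lower number a stronger inhibitor:
compound 1 `CC1=C(C(=O)O)C(c2cccc(Cl)c2)C(C(=O)OC/C=C/c2ccccc2)=C(C#N)N1`, 2000 nM
compound 2 `COC(OC)C1=C(C(=O)O)C(c2cccc(Cl)c2)C(C(=O)OC/C=C/c2ccccc2)=C(C)N1`, 1300 nM
compound 3 `COC(OC)C1=C(C(=O)OC/C=C/c2ccccc2Cl)C(c2cccc(Cl)c2)C(C(=O)O)=C(C)N1`, 700 nM

Compound 3 holds the lowest of the three numbers in this assay. Its nearest neighbour is compound 2, whose number sits within the usual scatter of repeated measurements, so the two cannot be ranked against each other. Compound 1 is the furthest, and its gap to compound 3 lies beyond the scatter.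

Compound 4 `COC(OC)C1=C(C(=O)OC/C=C/c2ccc(Cl)cc2)C(c2cccc(Cl)c2)C(C(=O)O)=C(C)N1` is built from compound 3 with the same atoms joined differently: 4-chlorophenyl in place of 2-chlorophenyl on a double-bonded chain carbon bound to a double-bonded chain carbon. Among the measured compounds shown here, no measured pair differs only in this way, so there is no precedent here for moving chlorine around on the ring of the ester chain. With nothing in the data pointing either way, the expectation is a step from compound 3 to compound 4 of a 1.1-fold higher number from compound 3 to compound 4 (0.06 log units; within the scatter), that is, none beyond the scatter. Compound 4 is therefore estimated at 800 nM in this assay, with a range from 300 nM to 2200 nM.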

Compound 4, half-maximal inhibitory concentration: 1400 nM
The estimate for compound 4 lay 1.8-fold (0.24 log units) below the measured number, within the range that was stated.
By their numbers in this assay, from the lowest: compounds 3, 2, 4 and 1 (each within the scatter of the next, the first and the last beyond it).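

In this assay the series now has its first pair differing in one place: 4-chlorophenyl in place of 2-chlorophenyl on a double-bonded chain carbon bound to a double-bonded chain carbon gives a 2.0-fold higher number from compound 3 to compound 4 (0.30 log units; within the scatter) and so does not separate the two compounds. At this place on the ester chain, then, compound 3 and compound 4 cannot be ranked, and the two chlorine patterns remain indistinguishable in this series. No independent measurement bears on this result.

As far as these compounds go, whether 3-chlorophenyl at the same place would also stay within the scatter of compound 3 remains open. So does the outcome of a different ring substituent there, such as 4-fluorophenyl or 4-methoxyphenyl, on the shared core.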